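Bromo on the core of compound 1

The source may hold more compounds than are shown below. What is called first, only, known or untested is meant among the compounds shown, and "the series" means these compounds.

compound 1 `COc1ccc(C(=O)n2c(-c3cn(C)c4ccccc34)nc3ccccc32)cc1OC` gives 8400 nM in the series
compound 2 `COc1cc(C(=O)n2c(-c3cn(C)c4ccccc34)nc3ccccc32)cc(OC)c1OC` gives 4300 nM in the series
compound 3 `Cn1cc(-c2nc3ccccc3n2C(=O)c2cccc(Br)c2)c2ccccc21` gives 61400 nM in the series

In a functional assay on HepG2 cells (Homo sapiens) for inhibition, read by MTT assay, with a stated time of 24 h (a lower number here means a stronger inhibitor of growth, a higher number a weaker inhibitor of growth), compound 1 at 8400 nM stands within the scatter of compound 2 and clearly apart from compound 3. Two measured steps change the group on the carbonyl carbon (a 2.0-fold lower number from compound 1 to compound 2 (0.29 log units; within the scatter)) and (a 7.3-fold higher number from compound 1 to compound 3 (0.86 log units; beyond the scatter)). Compound 4 `COc1ccc(C(=O)n2c(-c3cn(C)c4ccc(Br)cc34)nc3ccccc32)cc1OC` changes elsewhere (bromo in place of hydrogen on an aromatic carbon), with bromo in place of hydrogen on an aromatic carbon. Within the data shown here, no measured step touches that ring, and compound 3 carries bromine only on the other group, so neither step sets a direction. In this assay no step beyond the scatter is expected, the estimate being (a 1.2-fold lower number from compound 1 to compound 4 (0.08 log units; within the scatter)). Compound 4 is estimated at 7000 nM with an expected range of 2000 nM to 25000 nM for this measurement.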

Compound 4, concentration for 50% growth inhibition: 9700 nM
Compound 4: the middle estimate sits 1.4-fold (0.14 log units) below what was measured; measured number inside the range.
By their numbers in this assay, from the lowest: compounds 2, 1 and 4 (each within the scatter of the next, the first and the last beyond it); then compound 3.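

In this assay, among these compounds, the first change to this ring of the fused system gives a 1.2-fold higher number from compound 1 to compound 4 (0.06 log units; within the scatter), so bromo in place of hydrogen on this aromatic carbon produces no step beyond the scatter. Among the compounds shown here, the one step beyond the scatter remains the change on the carbonyl carbon, a 7.3-fold higher number from compound 1 to compound 3 (0.86 log units; beyond the scatter). For the compounds shown here, no evidence on the compounds bears on this result.

Open, as far as these compounds go, is whether an amine or a carboxylic acid on this carbon would also stay within the scatter. Also open, from the compounds shown here alone, is whether bromo here gives the same result with the carbonyl group of compound 2.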